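The source may report more compounds than this note shows. Statements on the series, on what has been measured and on what is new or still open speak of the compounds shown alone.

Among the measured compounds shown here, compound 2 `COc1ccc(/C=C2\CCCN=C2c2cccnc2)cc1` gives 490 nM in an assay on membranes from brain for displacement of a labelled ligand from Neuronal acetylcholine receptor; alpha4/beta2 (Rattus norvegicus), with a stated time of 3 h (on this read-out lower numbers stand for stronger inhibition and higher numbers for weaker inhibition), the lowest of the two numbers measured so far. For the measured compounds named here, compound 1 `FC(F)Oc1ccc(/C=C2\CCCN=C2c2cccnc2)cc1` gives 1160 nM in this assay, and the single measured step, a 2.4-fold lower number from compound 1 to compound 2 (0.37 log units; beyond the scatter), concerns an exchange on the oxygen rather than of the oxygen itself. Compound 3 `CSc1ccc(/C=C2\CCCN=C2c2cccnc2)cc1` carries methylsulfanyl in place of methoxy on an aromatic carbon. Going by the values given here, no measured step bears directly on this change, so the expectation is a step in this assay that is small, likely within the scatter or slightly toward a higher number, namely a 1.3-fold higher number from compound 2 to compound 3 (0.12 log units; within the scatter). Compound 3 is therefore estimated at 650 nM, with a range from 250 nM to 1700 nM.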

Compound 3, inhibition constant: 900 nM
The estimate for compound 3 lay 1.4-fold (0.14 log units) below the measured number; the range from low to high includes it.
By their numbers in this assay, from the lowest: compounds 2, 3 and 1 (each within the scatter of the next, the first and the last beyond it).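

Exchanging the oxygen itself at this position, on an aromatic carbon para to a large group, gives a step within the scatter in this assay (a 1.8-fold higher number from compound 2 to compound 3 (0.26 log units; within the scatter)), so methylsulfanyl is not told apart from methoxy here. Methylsulfanyl is not told apart from difluoromethoxy either (a 1.3-fold lower number from compound 1 to compound 3 (0.11 log units; within the scatter)), although compound 1 and compound 2 differ from each other beyond the scatter. No evidence is at hand to explain these numbers. Open, as far as these compounds go, is how an amine, a hydroxyl or an ethylsulfanyl group would fare at this position, and whether any exchange here gives a number clearly lower than that of compound 2.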